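From cyclohex-1-en-1-yl to cyclopropyl on a side chain

The source may hold more compounds than are shown below. What is called first, only, known or untested is meant among the compounds shown, and "the series" means these compounds.

- Compound 1 `COC(=O)CC/C=C\CC[C@H]1C(=O)C[C@@H](O)[C@@H]1/C=C/CC(C)(O)CCC1CC1`: 0.273 mg/kg
- Compound 2 `COC(=O)CC/C=C\CC[C@H]1C(=O)C[C@@H](O)[C@@H]1/C=C/C[C@@](C)(O)/C=C/C1=CCCCC1`: > 3.16 mg/kg (a limit of the assay, not a number)

Both results come from a functional assay on the whole organism with Rattus norvegicus as the target; a higher number here means that more compound is needed for the effect, a lower number that less compound is needed. As far as these compounds go, compound 2 has only a limit there, > 3.16 mg/kg, so its exact position on the scale is unknown.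

Compound 3 `COC(=O)CC/C=C\CC[C@H]1C(=O)C[C@@H](O)[C@@H]1/C=C/C[C@@](C)(O)/C=C/C1CC1` differs from compound 2 in one place: cyclopropyl in place of cyclohex-1-en-1-yl on a double-bonded chain carbon bound to a double-bonded chain carbon. In words, cyclopropyl stands in place of cyclohex-1-en-1-yl on a double-bonded chain carbon bound to a double-bonded chain carbon.

Within the data shown here, no measured step shows this change directly. Compound 1 also carries a cyclopropyl and gives 0.273 mg/kg, so a move towards less compound needed is expected, probably beyond the scatter. The expected change is a drop an at least 3.5-fold lower number from compound 2 to compound 3 (0.54 log units; beyond the scatter). Compound 3 is estimated at 0.9 mg/kg, with an expected range of 0.25 mg/kg to 3.2 mg/kg.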

Compound 3, dose for half-maximal effect: 0.402 mg/kg
For compound 3 the middle estimate is 2.2-fold (0.35 log units) above the measured one; measured number inside the range.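

In this assay, cyclopropyl in place of cyclohex-1-en-1-yl on this double-bonded chain carbon gives an at least 7.8-fold lower number from compound 2 to compound 3 (0.89 log units; beyond the scatter), the first direct measure of this change. Compound 2 has only a limit of the assay, so this step gives a minimum size and not an exact one: the limit of > 3.16 mg/kg in this assay, at which 1 of the 3 values shown sits. With cyclopropyl at the chain end, 3-cyclopropyl-1-hydroxy-1-methylprop-2-en-1-yl and 3-cyclopropyl-1-hydroxy-1-methylpropyl cannot be told apart, with a 1.5-fold higher number from compound 1 to compound 3 (0.17 log units; within the scatter).

The compounds shown leave open whether the gain follows from the three-membered ring itself, from the loss of the larger ring, or from the loss of that ring's double bond, and cyclohexyl at this place would help separate these. As far as these compounds go, how a phenyl or an open butyl chain would compare also remains unknown.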